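A Second Fluorine on a Fused Aromatic Core

A few compounds are considered here, and "the series" means these few. Any claim that something is new, unique, unknown or untested is made for them only; others in the source may bear on it.

Measured compounds:
compound 1 `NC(=O)/C=C1\CCc2c(F)cccc21` gives 40% in a functional assay on the whole organism with Rattus norvegicus as the target, at a dose of 20 mg/kg by the oral route; a lower number here means less inhibition, a higher number more inhibition at the dose given (going by the name of the read-out)
compound 2 `O=C(/C=C1\CCc2c(F)cc(F)cc21)NC1CC1` gives 38%
compound 3 `O=C(/C=C1\CCc2ccc(F)cc21)NC1CC1` gives 5%

Compound 3 and compound 2 share one core and differ by fluoro in place of hydrogen on an aromatic carbon. That step is a number 33 percentage points higher from compound 3 to compound 2 (beyond the scatter). Compound 1 stands on a different core; the difference between the two cores is not broken down here, and its value against compound 2 lies within the scatter.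

Compound 4 `NC(=O)/C=C1\CCc2c(F)ccc(F)c21` is not yet measured. It differs from compound 1 by fluoro in place of hydrogen on an aromatic carbon. Compared with the change from compound 3 to compound 2, the place differs: there the entering fluoro is meta to a fluoro group, here it is para to a fluoro group, so this is the same kind of change rather than the same one.

Because a number 33 percentage points higher from compound 3 to compound 2 (beyond the scatter) is large, compound 4 is expected to sit higher than compound 1, though the different place and core make the size uncertain. For compound 4 the expected step is a number 20 percentage points higher from compound 1 to compound 4 (beyond the scatter) in this assay. The estimate for compound 4 is 60%, with a range from 35% to 85%.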

Compound 4, a percentage reported as inhibition, in the whole organism at one dose (the size of the read-out at that dose, not a potency): 67%
Compound 4: middle estimate off by 7 percentage points, on the low side; low and high end bracket the measured number.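

In this assay, fluoro in place of hydrogen on an aromatic carbon again gave a clear rise, a number 27 percentage points higher from compound 1 to compound 4 (beyond the scatter). Set beside the earlier step, the change carried from one core to the other at much the same size: the same change on two cores in this assay, a number 33 percentage points higher (beyond the scatter) from compound 3 to compound 2 and a number 27 percentage points higher (beyond the scatter) from compound 1 to compound 4, 6 percentage points apart, within the scatter of two such steps. Within the data shown here, this rests on only two pairs, which differ in place as well as in core, with the entering fluoro para to a fluoro group in one pair and meta to a fluoro group in the other, so it does not show that the step would hold on a further core or at another place on the ring, nor does a read-out at a single dose show how potency changes.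

The compounds shown carry only fluoro on the aromatic ring, which leaves open whether chloro, methoxy or an amine at the same place would give a similar step. Going by these compounds, on the amide nitrogen they show only hydrogen and cyclopropyl, so the effect of a longer chain there on the size of the fluoro step also stays open.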